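Changing the aryl on the aromatic nitrogen: a limit-bound series

The source may hold more compounds than are shown below. What is called first, only, known or untested is meant among the compounds shown, and "the series" means these compounds.

Compounds measured so far, in an ADME assay on L02 cells (Homo sapiens) for antiproliferative activity, read by MTT assay, with a stated time of 48 h; on this read-out lower numbers stand for stronger inhibition and higher numbers for weaker inhibition:
Compound 1 `Cc1cccc(-n2nncc2CN2C(=O)C3(C(C#N)=C(N)Oc4c(N)cc5nc6ccccc6nc5c43)c3ccccc32)c1` gives > 50000 nM, a limit of the assay.
Compound 2 `N#CC1=C(N)Oc2c(N)cc3nc4ccccc4nc3c2C12C(=O)N(Cc1cnnn1-c1ccccc1Cl)c1ccccc12` gives > 50000 nM, a limit of the assay.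
Compound 3 `N#CC1=C(N)Oc2c(N)cc3nc4ccccc4nc3c2C12C(=O)N(Cc1cnnn1-c1ccc([N+](=O)[O-])cc1)c1ccccc12` gives > 50000 nM, a limit of the assay.

All three compounds share one core and differ only in the aryl group carried on an aromatic nitrogen. None of them yields a number: each result is a limit, and the limit of > 50000 nM in this assay, at which 3 of the 3 values shown sit, describes where all three sit. The step that the two limits leave unreadable from compound 1 to compound 2, the step that the two limits leave unreadable from compound 1 to compound 3 and the step that the two limits leave unreadable from compound 2 to compound 3 cannot be sized; each only shows that swapping one aryl for another left the read-out at the limit.

Compound 3 therefore stands at the limit, with the two other values keeping it company there. Compound 4 `N#CC1=C(N)Oc2c(N)cc3nc4ccccc4nc3c2C12C(=O)N(Cc1cnnn1-c1ccc(F)c(Cl)c1)c1ccccc12` is the next member of the series. Its change from compound 3 is 3-chloro-4-fluorophenyl in place of 4-nitrophenyl on an aromatic nitrogen.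

The measured steps all concern the same position and all ended at the limit, so they give no direction or size for this one. The expectation is that compound 4 behaves the same way, with a step that the limit leaves unreadable from compound 3 to compound 4 that most likely is not readable. Compound 4 is estimated at 60000 nM, within a range from 25000 nM to 150000 nM.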

Compound 4, half-maximal inhibitory concentration: > 50000 nM
Compound 4 gave a limit, no number; the forecaster's own chance of this, stated with the estimate: 80%; the middle value lies beyond the limit too.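

In this assay compound 4 gives > 50000 nM as a limit of the assay and not a number. Within the data shown here, no step among compound 1, compound 2, compound 3 and compound 4 can be read, because all four share one result: the limit of > 50000 nM in this assay, at which 4 of the 4 values shown sit.

The compounds shown leave open whether any aryl group at this position gives a measurable number, and how these four compare with one another.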